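The source may report more compounds than this note shows. Statements on the series, on what has been measured and on what is new or still open speak of the compounds shown alone.

Working notes on a series sharing a core, read in a functional assay on HL-60 cells (Homo sapiens) for cytotoxicity, read by MTT assay, with a stated time of 4 days; on this read-out higher numbers stand for weaker inhibition and lower numbers for stronger inhibition. Compound 1 `C=C1C[C@]23C[C@@]1(O)CC[C@@H]2c1cccc(C)c1[C@@H]3Cn1cc(-c2ccc(Cl)cc2)nn1` carries the 4-chlorophenyl. In this assay compound 1 stops at the limit > 20000 nM. Compound 2 `C=C1C[C@]23C[C@@]1(O)CC[C@@H]2c1cccc(C)c1[C@@H]3Cn1cc(-c2ccc(C)cc2)nn1` carries the 4-methylphenyl. In this assay compound 2 also stops at the limit > 20000 nM. The change between them, (chloro in place of methyl on an aromatic carbon), gives the step that the two limits leave unreadable from compound 2 to compound 1. Compound 3 `C=C1C[C@]23C[C@@]1(O)CC[C@H]2c1cc(Br)c(O)c(C)c1[C@@H]3Cn1cc(-c2ccc(C)cc2)nn1` sits on a second core; the difference between the two cores of compound 2 and compound 3 is not broken down here. In this assay compound 3 likewise stops at the limit > 20000 nM. Going by the values given here, every value so far sits at the limit of > 20000 nM in this assay, at which 3 of the 3 values shown sit, so no measured step can be sized. Compound 4 `C=C1C[C@]23C[C@@]1(O)CC[C@H]2c1cc(Br)c(O)c(C)c1[C@@H]3Cn1cc(-c2ccc(Cl)cc2)nn1` is not yet measured; it differs from compound 3 by chloro in place of methyl on an aromatic carbon, the same change, at the same place, as from compound 2 to compound 1. The step from compound 3 to compound 4 is expected to be a step that the limit leaves unreadable from compound 3 to compound 4, resting on the unreadable step that the two limits leave unreadable from compound 2 to compound 1 between the two matching compounds on the first core. Compound 4 is therefore estimated at 30000 nM, most likely again only a limit, with the range 15000 nM to 100000 nM.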

Compound 4, half-maximal inhibitory concentration: 5590 nM
Compound 4: the middle estimate sits 5.4-fold (0.73 log units) above what was measured; measured number outside the range, below it.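

In this assay, chloro in place of methyl on the second core gives an at least 3.5-fold lower number from compound 3 to compound 4 (0.55 log units; beyond the scatter). This is a minimum size only, and the same change on the first core cannot be read, so the series does not show whether the change carries from one core to the other with a similar size: the limit of > 20000 nM in this assay, at which 3 of the 4 values shown sit. The 4-chlorophenyl gives a measured number only in compound 4, while compound 1, which carries it on the first core, stays at a limit, so one readable pair sets no pattern across the two cores.

Which difference between the two cores goes with the measured number for compound 4 remains open. Also open, as far as these compounds go, is how an amine, a carboxylic acid or a methoxy group would read in place of the chloro on the second core.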